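The compounds below may be only part of what the source reports. "The series", "measured", "known", "first", "only" and "open" are said of these compounds alone.

Of the compounds shown here, three have so far been measured in a functional assay on PC-3 cells (Homo sapiens) for cytotoxicity, read by MTT assay, with a stated time of 72 h; a higher number here means a weaker inhibitor of growth, a lower number a stronger inhibitor of growth. Compound 1 `CCCOC(=O)Nc1ccc([Se]C#N)cc1` gives 47400 nM. Compound 2 `CCOC(=O)Nc1ccc([Se][Se]c2ccc(NC(=O)OCC)cc2)cc1` gives 52200 nM, and compound 3 `Cc1ccc(OC(=O)Nc2ccc([Se][Se]c3ccc(NC(=O)Oc4ccc(C)cc4)cc3)cc2)cc1` gives 28200 nM. Compound 1 thus stands second highest of the three numbers; its nearest neighbour is compound 2 and its furthest is compound 3, and both gaps lie within the usual scatter of the method, so no order can be read among the three.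

Compound 4 `C=CCOC(=O)Nc1ccc([Se]C#N)cc1` has not yet been measured. It differs from compound 1 in one place: vinyl in place of ethyl on a saturated chain carbon bound to an oxygen next to a carbonyl group. For the measured compounds named here, no measured pair shows this change, so no step size for it is known from the numbers at hand. The rest of compound 1 stays untouched, and the expectation is that the step in this assay is none beyond the scatter, estimated as a 1.1-fold lower number from compound 1 to compound 4 (0.02 log units; within the scatter). Compound 4 is therefore expected to give 45000 nM in this assay, with a range from 20000 nM to 100000 nM.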

Compound 4, concentration for total growth inhibition: 44700 nM
Compound 4: middle estimate off by 1.0-fold (0.00 log units), on the high side; low and high end bracket the measured number.
By their numbers in this assay, from the lowest: compounds 3, 4, 1 and 2 (each within the scatter of the next).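

The exchange of propyl for allyl, on a saturated chain carbon bound to an oxygen next to a carbonyl group, gives in this assay a 1.1-fold lower number from compound 1 to compound 4 (0.03 log units; within the scatter). For the compounds shown here, the earlier compounds included no pair differing in one place, so this is the first step that can be read, and it shows that a double bond can enter this chain with no step beyond the scatter. Nothing at hand accounts for this result.

What the compounds shown leave open is whether a longer chain, a terminal amine or a carboxylic acid in place of allyl would move the number beyond the scatter. Also open, as far as these compounds go, is whether the same exchange would read alike on the core of compound 2.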